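Anilino in place of benzyl on the shared core

A few compounds are considered here, and "the series" means these few. Any claim that something is new, unique, unknown or untested is made for them only; others in the source may bear on it.

Compound 1 `COc1ccc(Cc2nnc(CN(c3cccc(Cl)c3C)S(=O)(=O)c3ccc(C)cc3)o2)cc1` and compound 2 `CCOc1ccc(Cc2nnc(CN(c3cccc(Cl)c3Cl)S(=O)(=O)c3ccc(C(F)(F)F)cc3)o2)cc1` have been measured in an assay on CHO cells for displacement of a labelled ligand from prostaglandin E2 receptor EP1 subtype (Homo sapiens); on this read-out lower numbers stand for stronger inhibition and higher numbers for weaker inhibition. Compound 1 gives 6.31 nM, the higher of the two numbers; compound 2 gives 2.51 nM, and the gap between them lies beyond the scatter. Compound 3 `COc1ccc(Nc2nnc(CN(c3cccc(Cl)c3C)S(=O)(=O)c3ccc(C)cc3)o2)cc1` differs from compound 1 in one place: (4-methoxyphenyl)amino in place of 4-methoxybenzyl on an aromatic carbon. For the measured compounds named here, no measured pair shows this change, so its direction is open; a modest step from compound 1 to compound 3, hardly beyond the scatter either way, is expected. For compound 3 in this assay the estimated value is 8 nM, within 3 nM to 25 nM. The expected step is a 1.3-fold higher number from compound 1 to compound 3 (0.10 log units; within the scatter).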

Compound 3, half-maximal inhibitory concentration: 31.6 nM
Compound 3: the middle estimate sits 4.0-fold (0.60 log units) below what was measured, outside the stated range (above it).
By their numbers in this assay, from the lowest: compound 2; then compound 1; then compound 3.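

In this assay (4-methoxyphenyl)amino in place of 4-methoxybenzyl on this aromatic carbon gives a 5.0-fold higher number from compound 1 to compound 3 (0.70 log units; beyond the scatter) and so shows that this position responds to the change, although the heavy-atom count and the six-membered aromatic ring stay the same. The entering group adds a hydrogen-bond donor, but no measurement at hand explains the step.

Whether the amino hydrogen matters stays open, as the compounds shown include neither a methyl-substituted amino link nor an ether oxygen in this place. As far as these compounds go, whether the step carries over to the other substituents of compound 2 is also open.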